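The compounds below may be only part of what the source reports. "The series", "measured", "known", "first", "only" and "open" are said of these compounds alone.

Series notes: in a functional assay on A549 cells (Homo sapiens) for antiproliferative activity, read by MTT assay, with a stated time of 72 h (a lower number here means a stronger inhibitor, a higher number a weaker inhibitor), compound 2 (`C=CC(=O)Nc1cc(Nc2nccc(NC(=O)c3ccccc3)n2)c(OC)cc1N(C)CCN(C)C`) gives 1740 nM and compound 1 (`C=CC(=O)Nc1cc(Nc2nccc(NC(=O)c3cccc(OC)c3)n2)c(OC)cc1N(C)CCN(C)C`) gives 3000 nM. Among the compounds with values here, compound 2 therefore stands within the scatter of the only other measured compound, and the two numbers cannot be ranked.

Next in the series is compound 3 (`C=CC(=O)Nc1cc(Nc2nccc(NC(=O)c3ccc(C(F)(F)F)cc3)n2)c(OC)cc1N(C)CCN(C)C`), which carries trifluoromethyl in place of hydrogen on an aromatic carbon of the benzoyl ring of compound 2, para to a large group: trifluoromethyl in place of hydrogen on an aromatic carbon. The shared core and the rest of the molecule stay the same.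

Within the data shown here, only one measured step bears on this change, and it is the exchange of methoxy for hydrogen on the same ring: a 1.7-fold lower number from compound 1 to compound 2 (0.24 log units; within the scatter). That step is small and involves a different group, so it offers only weak guidance. Among the measured compounds shown here, no measured compound carries trifluoromethyl, and the data give no direction for adding it. No shift beyond the scatter is therefore expected in this assay, although the uncertainty is wide.

The expected step is a 1.0-fold higher number from compound 2 to compound 3 (0.01 log units; within the scatter). For compound 3 the estimated value is 1800 nM, with an expected range from 600 nM to 5000 nM.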

Compound 3, half-maximal inhibitory concentration: 9880 nM
Compound 3: the middle estimate sits 5.5-fold (0.74 log units) below what was measured; the measured number lies above the stated range.
By their numbers in this assay, from the lowest: compounds 2 and 1 (each within the scatter of the next); then compound 3.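

In this assay, within the data shown here, trifluoromethyl in place of hydrogen on the benzoyl ring, para to a large group, gives a 5.7-fold higher number from compound 2 to compound 3 (0.75 log units; beyond the scatter), the first change in this short series whose size lies beyond the scatter. The earlier exchange of methoxy for hydrogen could not show that substitution on this ring can move the number, and this step shows that it can, with the number rising and activity weakening. The exchange of 3-methoxyphenyl for 4-(trifluoromethyl)phenyl gives a 3.3-fold higher number from compound 1 to compound 3 (0.52 log units; beyond the scatter), so compound 3 is the weakest of the three, and no measurement on hand bears on what lies behind this loss.

The compounds shown leave open whether the rise belongs to trifluoromethyl itself or would follow any group at this place, a question that a single fluorine, a methyl, a nitrile or an amine on the same aromatic carbon would help to settle. They also leave open whether any substituent on this ring can lower the number beyond the scatter, since neither group seen so far does so relative to the unsubstituted benzoyl of compound 2.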